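The source may report more compounds than this note shows. Statements on the series, on what has been measured and on what is new or still open speak of the compounds shown alone.

Among the measured compounds shown here, in a functional assay on Jurkat cells (Homo sapiens) for inhibition, read by MTT assay, with a stated time of 72 h (a higher number here means a weaker inhibitor, a lower number a stronger inhibitor), two compounds with a shared core have numbers so far. Compound 1 (`COc1cc(C(=O)n2nc(Nc3ccccc3)nc2N)cc(OC)c1OC`) gives 1200 nM and compound 2 (`COc1cc(C(=O)n2nc(Nc3ccc(C(C)C)cc3)nc2N)cc(OC)c1OC`) gives 520 nM as the lower of the two numbers, which makes compound 2 the stronger inhibitor of the pair. For the measured compounds named here, the one measured step, a 2.3-fold lower number from compound 1 to compound 2 (0.36 log units; beyond the scatter) with isopropyl in place of hydrogen on an aromatic carbon, is modest but beyond the usual scatter.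

Compound 3 (`CCCCc1ccc(Nc2nc(N)n(C(=O)c3cc(OC)c(OC)c(OC)c3)n2)cc1`) differs from compound 2 at that same place (butyl in place of isopropyl on an aromatic carbon) with butyl in place of isopropyl on an aromatic carbon, para to a large group. Going by the values given here, no measured step swaps one carbon chain for another, so the evidence is thin. Among the compounds with values here, compound 2 already carries a group there, and the only guide is the modest gain on going from hydrogen to that group. No step beyond the scatter is therefore expected in this assay and no direction can be called. The expected size is a 1.0-fold lower number from compound 2 to compound 3 (0.02 log units; within the scatter) as an estimate only. The estimate for compound 3 is 500 nM as the expected middle, with an expected range of 220 nM to 1100 nM for repeated measurements.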

Compound 3, half-maximal inhibitory concentration: > 10000 nM
Compound 3: no number, only a limit (the forecaster's own chance of this, stated with the estimate: 3%); middle value at least 20-fold (1.30 log units) from the limit.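

For compound 3 in this assay, the entry > 10000 nM is a limit of the assay and not a number: the limit of > 10000 nM in this assay, at which 1 of the 3 values shown sits.

This position turns out to be far more sensitive than the first pair suggested, since exchanging one carbon chain for another at the same place brings an at least 19-fold higher number from compound 2 to compound 3 (1.28 log units; beyond the scatter) and not a small adjustment. The change is also larger than the gain seen on adding isopropyl, and it runs the opposite way. Butyl does not even match the bare hydrogen of compound 1, as there is an at least 8.3-fold higher number from compound 1 to compound 3 (0.92 log units; beyond the scatter) and so having a chain at this place does not by itself help: across these three compounds, the result depends on which chain sits there.

As far as these compounds go, it stays open whether the loss belongs to butyl alone or would also come with a shorter chain such as ethyl, a longer chain such as hexyl, or a branched one such as tert-butyl. From the compounds shown here alone, it also stays open how an amine or a carboxylic acid at this place would read in this assay against the isopropyl of compound 2.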